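The compounds below may be only part of what the source reports. "The series", "measured", "known", "first", "only" and "open" are said of these compounds alone.

In a functional assay on SK-MEL-2 cells (Homo sapiens) for cytotoxicity (on this read-out higher numbers stand for weaker inhibition and lower numbers for stronger inhibition), two compounds have been measured so far. Compound 1 `Cc1ccc(-c2cc3cc(C)ccc3c(O)n2)cc1` gives 7760 nM, and compound 2 `COc1ccc(-c2cc3cc(C)ccc3c(N3CCN(C)CC3)n2)cc1` gives 3710 nM. Compound 2 therefore holds the lower of the two numbers, and its gap to compound 1 lies beyond the scatter, which makes it the stronger inhibitor of this pair. The next compound to be tested is compound 3 `Cc1ccc(-c2cc3cc(C)ccc3c(N3CCN(C)CC3)n2)cc1`, which differs from compound 2 in one place: methyl in place of methoxy on an aromatic carbon. In words, this is methyl in place of methoxy on an aromatic carbon, para to a large group. Among the compounds with values here, no measured pair yet shows a single change of this kind, so the data offer no direct guide and no direction can be favoured. The expected result is a 1.0-fold lower number from compound 2 to compound 3 (0.01 log units; within the scatter), a step estimated to stay within the scatter. In this assay, compound 3 is estimated at 3600 nM, with an expected range from 1500 nM to 8500 nM.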

Compound 3, half-maximal inhibitory concentration: 2400 nM
Compound 3: the middle estimate sits 1.5-fold (0.18 log units) above what was measured, and the stated range covers the measured number.
By their numbers in this assay, from the lowest: compounds 3 and 2 (each within the scatter of the next); then compound 1.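

In this assay, the 4-methoxyphenyl of compound 2 and the 4-methylphenyl of compound 3 cannot be told apart: methyl in place of methoxy on this aromatic carbon, para to a large group, gives a 1.5-fold lower number from compound 2 to compound 3 (0.19 log units; within the scatter) and so has no clear effect here. Within the data shown here, compound 3 also provides the first single-change comparison at the other site, where 4-methylpiperazin-1-yl in place of hydroxy gives a 3.2-fold lower number from compound 1 to compound 3 (0.51 log units; beyond the scatter) and so brings a modest but real gain in inhibition. No measurement at hand offers a reason for either step.

From the compounds shown here alone, whether a chlorine atom or a dimethylamino group in the methyl position would also leave the number unchanged remains open, as does whether a piperidine or morpholine ring could stand in for the 4-methylpiperazin-1-yl group. Going by these compounds, each change also rests on a single pair, so its size on other compounds is unknown.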